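This account rests on a few compounds, and the source may have more. Where it says the series, first, only, none or still open, it means among the compounds named here.

For the measured compounds named here, in an assay on isolated protein for inhibition of Type-2 angiotensin II receptor (Rattus norvegicus) (on this read-out higher numbers stand for weaker inhibition and lower numbers for stronger inhibition), compound 2 `CCCc1nc(CC)c(C(=O)CCN(C(=O)c2ccncc2)c2ccccc2)n1Cc1ccc(-c2ccccc2S(=O)(=O)NC(=O)OCCC(C)C)cc1F` gives 0.1 nM; the only other number comes from compound 1 `CCCC(=O)N(CCC(=O)c1c(CC)nc(CCC)n1Cc1ccc(-c2ccccc2S(=O)(=O)NC(=O)OCCC(C)C)cc1F)c1ccccc1`, which gives 0.15 nM, and the step of a 1.5-fold lower number from compound 1 to compound 2 (0.18 log units; within the scatter) is within the scatter, so the two compounds cannot be told apart on this read-out. Compound 3 `CCCc1nc(CC)c(C(=O)CCN(C(=O)c2ccncc2)c2cccnc2)n1Cc1ccc(-c2ccccc2S(=O)(=O)NC(=O)OCCC(C)C)cc1F` is not yet measured and differs from compound 2 by pyridin-3-yl in place of phenyl on an amide-type nitrogen. Going by the values given here, no measured step touches that place, and the single step shown sits on a carbonyl carbon and is within the scatter. Compound 3 is therefore expected to show a 1.5-fold higher number from compound 2 to compound 3 (0.18 log units; within the scatter), nothing beyond the scatter. For compound 3 the estimate in this assay is 0.15 nM, in a range from 0.05 nM to 0.5 nM.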

Compound 3, half-maximal inhibitory concentration: 1 nM
Beside the measured number, compound 3's estimate is 6.7-fold (0.82 log units) below it; measured number outside the range, above it.
By their numbers in this assay, from the lowest: compounds 2 and 1 (each within the scatter of the next); then compound 3.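

In this assay, the amide-type nitrogen is the only place among these compounds where a change moves the number beyond the scatter: pyridin-3-yl in place of phenyl gives a 10-fold higher number from compound 2 to compound 3 (1.00 log units; beyond the scatter) with the heavy-atom count unchanged. The entering ring differs by one ring nitrogen and one hydrogen-bond acceptor, so this position is sensitive to a small change. Nothing available gives a reason for this step.

The compounds shown leave open whether pyridin-2-yl or pyridin-4-yl on this nitrogen would give a similar number. They also leave open whether the same change would give a similar step with propyl on the carbonyl carbon.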